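From compound 2 to compound 3: furan-2-yl replaces 3-chlorophenyl

The source may report more compounds than this note shows. Statements on the series, on what has been measured and on what is new or still open speak of the compounds shown alone.

Compound 2 `CC1=CC[C@H](C(C)(C)NC(=S)N/N=C/c2cccc(Cl)c2)CC1` carries a 3-chlorophenyl group on a carbon with a double bond to nitrogen. In a functional assay on K562 cells (Homo sapiens) for inhibition, read by sulforhodamine B assay, with a stated time of 48 h (on this read-out higher numbers stand for weaker inhibition of growth and lower numbers for stronger inhibition of growth), compound 2 gives only a limit, > 100000 nM, and no number. Its closest measured relative, compound 1 `COc1ccc(/C=N/NC(=S)NC(C)(C)[C@H]2CC=C(C)CC2)cc1`, differs only in having 4-methoxyphenyl on that carbon, and in this assay compound 1 gives 30700 nM. The step of an at least 3.2-fold higher number from compound 1 to compound 2 (0.51 log units; beyond the scatter) shows that exchanging the aryl group at this carbon can move the read-out beyond the scatter, with the 3-chlorophenyl compound sitting at the limit of > 100000 nM in this assay, at which 1 of the 2 values shown sits.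

Compound 3 `CC1=CC[C@H](C(C)(C)NC(=S)N/N=C/c2ccco2)CC1` is the next variation at the same place: furan-2-yl in place of 3-chlorophenyl on a carbon with a double bond to nitrogen. Among the compounds with values here, no measured step involves furan-2-yl, so the single step just quoted is the only guide, and it does not fix a direction. Compound 2 stands at the limit, so a lower number is possible in principle, while a value at the limit again is at least as likely. Compound 3 is therefore expected to land near 90000 nM, between 25000 nM and 300000 nM. As a step, the estimate for compound 3 means an at least 1.1-fold lower number from compound 2 to compound 3 (0.04 log units; that floor lies within the scatter).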

Compound 3, concentration for total growth inhibition: > 100000 nM
Compound 3: no number, only a limit; the forecaster's own chance of this, stated with the estimate: 55%; middle value at least 1.1-fold (0.04 log units) away from the limit.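

With furan-2-yl on the carbon with a double bond to nitrogen, a five-membered aromatic ring with an oxygen joins the six-membered 3-chlorophenyl ring in giving no number. In this assay compound 3 gives > 100000 nM, which is a limit of the assay and not a number. Measured against the 4-methoxyphenyl compound, the change is an at least 3.2-fold higher number from compound 1 to compound 3 (0.51 log units; beyond the scatter), so among the three groups shown at this place only 4-methoxyphenyl gives a measurable value, while compound 2 and compound 3 cannot be ordered and the step between them cannot be read, because both stand at the same limit: the limit of > 100000 nM in this assay, at which 2 of the 3 values shown sit.

The compounds shown leave open whether a 4-hydroxyphenyl or a 4-dimethylaminophenyl group on this carbon would give a number, and how such a number would compare with that of compound 1. They also do not tell whether it is the methoxy group or the phenyl ring of the 4-methoxyphenyl group that separates compound 1 from compound 3.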